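Swapping the methoxyphenyl for a dimethylphenyl

This account rests on a few compounds, and the source may have more. Where it says the series, first, only, none or still open, it means among the compounds named here.

Of the compounds shown here, two sharing one core have been measured in a functional assay on HCT-116 cells (Homo sapiens) for antiproliferative activity, read by MTT assay, with a stated time of 48 h; on this read-out higher numbers stand for weaker inhibition of growth and lower numbers for stronger inhibition of growth. Compound 1 `S=C(Nc1ccccc1)N1N=C(c2ccccc2)CC1c1ccc2c(c1)OCCO2` gives 57600 nM in this assay. Compound 2 `COc1ccccc1C1=NN(C(=S)Nc2ccccc2)C(c2ccc3c(c2)OCCO3)C1` carries a methoxy on an aromatic carbon where compound 1 carries hydrogen. In this assay compound 2 reaches only the limit of > 200000 nM, a boundary of the assay rather than a number. For the measured compounds named here, the single measured step, an at least 3.4-fold higher number from compound 1 to compound 2 (0.54 log units; beyond the scatter), therefore shows that adding the methoxy weakened growth inhibition, and the limit of > 200000 nM in this assay, at which 1 of the 2 values shown sits, is the reason the full size of that loss is not known.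

Compound 3 `Cc1ccc(C2=NN(C(=S)Nc3ccccc3)C(c3ccc4c(c3)OCCO4)C2)cc1C` is the unmeasured compound. Its change from compound 2 is 3,4-dimethylphenyl in place of 2-methoxyphenyl on a carbon with a double bond to nitrogen. Going by the values given here, this change removes the methoxy that brought the loss in the measured step, yet it also adds two methyls, for which no measured step exists. A return toward the number of compound 1 seems plausible, but with wide uncertainty, so only a modest step in the direction of stronger inhibition is expected, an at least 2.0-fold lower number from compound 2 to compound 3 (0.30 log units; that floor lies within the scatter). Compound 3 is estimated at 100000 nM, within a range from 30000 nM to 300000 nM, because compound 1 gives 57600 nM.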

Compound 3, concentration for 50% growth inhibition: 144000 nM
For compound 3 the middle estimate is 1.4-fold (0.16 log units) below the measured one; the measured number falls inside the stated range.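

The 3,4-dimethylphenyl group on this carbon with a double bond to nitrogen does not bring back the level of the plain phenyl: in this assay the change gives a 2.5-fold higher number from compound 1 to compound 3 (0.40 log units; beyond the scatter). With compound 2 and compound 3 both giving higher numbers than compound 1, neither of the two substituted phenyl groups shown at this position matches the unsubstituted one, so the loss seen earlier is not confined to the 2-methoxyphenyl group. Against the 2-methoxyphenyl group itself the change gives an at least 1.3-fold lower number from compound 2 to compound 3 (0.14 log units; that floor lies within the scatter), and the real size of this step stays unknown because compound 2 stands at a limit of the assay rather than at a number: the limit of > 200000 nM in this assay, at which 1 of the 3 values shown sits.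

The compounds shown do not separate the contributions of the two methyls, and a phenyl carrying one methyl alone could show whether a single methyl already brings the loss. Nor do they tell how this position responds to a phenyl carrying a chlorine, a hydroxyl or an amine, any of which could show whether some substituent here matches or improves on compound 1.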